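Repositioning the triazole carbamoyl in a dihydropyridine series

The compounds below may be only part of what the source reports. "The series", "measured", "known", "first", "only" and "open" are said of these compounds alone.

For the measured compounds named here, compound 1 `CCO/C(O)=C1\C(COCCn2nncc2C(N)=O)=NC(C)=C(C(=O)OC)C1c1ccccc1Cl` gives 100 nM in a functional assay (aorta) with Rattus norvegicus as the target (on this read-out lower numbers stand for stronger inhibition and higher numbers for weaker inhibition), the highest of the three numbers measured so far. Compound 3 `CCO/C(O)=C1\C(COCCn2ccnn2)=NC(C)=C(C(=O)OC)C1c1ccccc1Cl` gives 15.9 nM in this assay, and compound 2 `CCO/C(O)=C1\C(COCCn2cc(C(N)=O)nn2)=NC(C)=C(C(=O)OC)C1c1cccc(Cl)c1Cl` gives 3.16 nM. Going by the values given here, the one measured step that touches the triazole, a 6.3-fold lower number from compound 1 to compound 3 (0.80 log units; beyond the scatter), shows that losing the carbamoyl from its position in compound 1 lowers the number by a modest but real margin. Compound 4 `CCO/C(O)=C1\C(COCCn2cc(C(N)=O)nn2)=NC(C)=C(C(=O)OC)C1c1ccccc1Cl` differs from compound 1 as 4-carbamoyl-1H-1,2,3-triazol-1-yl in place of 5-carbamoyl-1H-1,2,3-triazol-1-yl on a saturated chain carbon, two bonds along the chain from an oxygen on a saturated carbon. Among the compounds with values here, no measured pair isolates this rearrangement; compound 2 carries the same 4-carbamoyl arrangement but also a different aryl ring, so its value only shows that this arrangement is compatible with a low number. Taking the step to compound 3 as a floor for what moving the group away from its present position can give, the expected change is an 8.3-fold lower number from compound 1 to compound 4 (0.92 log units; beyond the scatter), a lower number. The estimate for compound 4 in this assay is 12 nM, with a range from 3 nM to 45 nM.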

Compound 4, half-maximal inhibitory concentration: 20 nM
The estimate for compound 4 lay 1.7-fold (0.22 log units) below the measured number; low and high end bracket the measured number.
By their numbers in this assay, from the lowest: compound 2; then compounds 3 and 4 (each within the scatter of the next); then compound 1.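

In this assay the step of a 5.0-fold lower number from compound 1 to compound 4 (0.70 log units; beyond the scatter) isolates the rearrangement on the triazole: with the same atoms, joined differently, the 4-carbamoyl-1H-1,2,3-triazol-1-yl group gives a lower number than the 5-carbamoyl-1H-1,2,3-triazol-1-yl group. The step of a 1.3-fold higher number from compound 3 to compound 4 (0.10 log units; within the scatter) leaves the 4-carbamoyl compound level with the compound bearing hydrogen in place of carbamoyl, so the high number of compound 1 goes with the 5-carbamoyl arrangement and not with carbamoyl as such. The step of a 6.3-fold higher number from compound 2 to compound 4 (0.80 log units; beyond the scatter) shows that the low number of compound 2 does not come from the 4-carbamoyl arrangement alone, since the chloro change also counts.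

Open, going by these compounds, is whether a carboxylic acid or a nitrile in place of carbamoyl would match these numbers, and whether the chloro step holds with the 5-carbamoyl group. No measurement offered here explains any of these differences.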